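The compounds below may be only part of what the source reports. "The series", "measured", "known", "first", "only" and "open" are said of these compounds alone.

Measured in a functional assay on HeLa cells (Homo sapiens) for antiproliferative activity, read by MTT assay, with a stated time of 48 h; a lower number here means a stronger inhibitor, a higher number a weaker inhibitor:
Compound 1 `COc1ccc(N(C)c2ccnc(Cl)n2)cc1`: 917 nM
Compound 2 `COc1ccc(N(C)c2ccnc(Cl)n2)cc1Cl`: 517 nM
Compound 3 `COc1ccc(N(C)c2ccnc(Cl)n2)cc1O`: 96 nM

Compound 3 has the lowest number of the three, clearly apart from both others. Compound 4 `COc1ccc(N(C)c2ccnc(Cl)n2)cc1OCCCCBr` is derived from it by 4-bromobutyl in place of hydrogen on an oxygen on an aromatic ring, with 4-bromobutyl in place of hydrogen on an oxygen on an aromatic ring. Among the compounds with values here, two measured steps bear on this: a 9.6-fold lower number from compound 1 to compound 3 (0.98 log units; beyond the scatter) and a 5.4-fold lower number from compound 2 to compound 3 (0.73 log units; beyond the scatter), both modest and beyond the scatter. The step of a 1.8-fold lower number from compound 1 to compound 2 (0.25 log units; within the scatter) stays within the scatter. Within the data shown here, no measured compound carries a chain on that oxygen, so the evidence is indirect. With the hydroxy hydrogen gone, part of the gain seen in a 9.6-fold lower number from compound 1 to compound 3 (0.98 log units; beyond the scatter) is expected to be lost. The expected change is a modest rise, a 3.1-fold higher number from compound 3 to compound 4 (0.49 log units; beyond the scatter). Compound 4 is estimated at 300 nM, with an expected range of 70 nM to 1300 nM.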

Compound 4, half-maximal inhibitory concentration: 307 nM
Compound 4: the middle estimate sits 1.0-fold (0.01 log units) below what was measured; the measured number falls inside the stated range.
By their numbers in this assay, from the lowest: compound 3; then compounds 4, 2 and 1 (each within the scatter of the next, the first and the last beyond it).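

In this assay, 4-bromobutyl on the oxygen costs part of the activity of the free hydroxy, with a 3.2-fold higher number from compound 3 to compound 4 (0.50 log units; beyond the scatter), so this oxygen takes a long chain at a measurable cost. That cost does not remove the whole gain over the unsubstituted position, as a 3.0-fold lower number from compound 1 to compound 4 (0.48 log units; beyond the scatter) shows. Against chloro at the same place there is no separation, with a 1.7-fold lower number from compound 2 to compound 4 (0.23 log units; within the scatter).

The compounds shown leave open whether a shorter or longer chain, or an amine or carboxylic acid in place of the bromine, would change this number. Nothing at hand gives a cause for these steps.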